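A few compounds are considered here, and "the series" means these few. Any claim that something is new, unique, unknown or untested is made for them only; others in the source may bear on it.

Compound 3 `C#CCNC1CCc2c(SCc3ccccc3)cccc21` gives "not active" (no number reported) in an ADME assay on isolated protein for inhibition of Amine oxidase [flavin-containing] B (Homo sapiens) (on this read-out lower numbers stand for stronger inhibition and higher numbers for weaker inhibition), with no number reported, so it stands nowhere on the scale set by the other two compounds. Compound 1 `C#CCNC1CCc2c(SCc3cccc(F)c3)cccc21` gives 11600 nM in this assay, and compound 2 `C#CCNC1CCc2c(SCc3ccc(C)cc3)cccc21` gives 320 nM, the step of a 36-fold lower number from compound 1 to compound 2 (1.56 log units; beyond the scatter) being large. Compound 4 `C#CCNC1CCc2c(SCc3cccc(Br)c3)cccc21` differs from compound 3 by bromo in place of hydrogen on an aromatic carbon. For the measured compounds named here, no measured step carries a bromine, but compound 1 shows that a halogen on the same ring position yields a measurable, if weak, number where the bare phenyl of compound 3 yields none. Compound 4 is therefore expected to fall in the weak range, estimated at 8000 nM with a range from 1500 nM to 40000 nM.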

Compound 4, half-maximal inhibitory concentration: > 100000 nM
Compound 4 was reported as a limit; the forecaster's own chance of this, stated with the estimate: 30%; middle value at least 12-fold (1.09 log units) away from the limit.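

In this assay the reading for compound 4 is a limit, not a number: the limit of > 100000 nM in this assay, at which 1 of the 4 values shown sits. A halogen at this place therefore does not by itself give a measurable number, since bromo in place of fluoro brings an at least 8.6-fold higher number from compound 1 to compound 4 (0.93 log units; beyond the scatter), and 3-bromophenyl in place of 4-methylphenyl brings an at least 310-fold higher number from compound 2 to compound 4 (2.49 log units; beyond the scatter). Compound 3 has no number, so the change from hydrogen to bromo cannot be sized. The compounds shown leave open whether the gain in compound 2 belongs to the methyl group or to its place on the ring, which a 3-methylphenyl group would separate.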